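The compounds below may be only part of what the source reports. "The series", "measured", "known", "first", "only" and "open" are said of these compounds alone.

Among the measured compounds shown here, compound 2 `CN(C1CCN(CCCc2c[nH]c3ccc(-n4cnnc4)cc23)CC1)S(=O)(=O)c1ccccc1` stands lowest of the two numbers so far in an assay on CHO cells for displacement of a labelled ligand from 5-hydroxytryptamine receptor 1B (Homo sapiens) (a higher number here means a weaker inhibitor, a lower number a stronger inhibitor), where compound 2 gives 10 nM. For the measured compounds named here, the only other measured compound is compound 1 `CN(Cc1cccs1)C1CCN(CCCc2c[nH]c3ccc(-n4cnnc4)cc23)CC1`, and in this assay compound 1 gives 140 nM. Going by the values given here, the single measured step, a 14-fold lower number from compound 1 to compound 2 (1.15 log units; beyond the scatter), is large and goes well beyond the scatter, with the phenylsulfonyl compound showing the lower number.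

Compound 3 `CC(C)=CCN(C)C1CCN(CCCc2c[nH]c3ccc(-n4cnnc4)cc23)CC1` is not yet measured. Its change from compound 2 is 3-methylbut-2-en-1-yl in place of phenylsulfonyl on an amine nitrogen. The group that leaves is the same phenylsulfonyl that distinguishes compound 2 from compound 1, and what enters is a chain with no ring, as the thiophen-2-ylmethyl of compound 1 was a group without sulfonyl. The step of a 14-fold lower number from compound 1 to compound 2 (1.15 log units; beyond the scatter) therefore bears directly on this change, and since it was large, a step of similar size in the opposite direction is expected for compound 3, estimated as a 15-fold higher number from compound 2 to compound 3 (1.18 log units; beyond the scatter). Compound 3 is thus expected to give about 150 nM in this assay, within a range from 50 nM to 500 nM.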

Compound 3, half-maximal inhibitory concentration: 41 nM
The estimate for compound 3 lay 3.7-fold (0.56 log units) above the measured number; the measured number lies below the stated range.
By their numbers in this assay, from the lowest: compound 2; then compound 3; then compound 1.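

On this amine nitrogen, the loss of phenylsulfonyl costs far less when 3-methylbut-2-en-1-yl enters than the step from compound 1 alone suggested: in this assay there is a 4.1-fold higher number from compound 2 to compound 3 (0.61 log units; beyond the scatter). A group with no ring and no sulfonyl therefore comes closer to phenylsulfonyl than the (thiophen-2-yl)methyl group does, as a 3.4-fold lower number from compound 1 to compound 3 (0.53 log units; beyond the scatter) shows, so the two groups without sulfonyl also differ from each other beyond the scatter and the presence or absence of sulfonyl does not alone set the number. No measurement shown here explains the order of the three compounds.

The compounds shown leave open whether the low number of compound 2 goes with the sulfonyl or with the phenyl ring, a question that a benzyl or a methylsulfonyl group on the same nitrogen would help to separate. They also leave open whether the double bond of 3-methylbut-2-en-1-yl matters, which the saturated 3-methylbutyl chain would test.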